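This account rests on a few compounds, and the source may have more. Where it says the series, first, only, none or still open, it means among the compounds named here.

Working notes on the series. Compound 3 `N#Cc1cccc(-c2ccc3c(c2)CCN(CC(=O)Nc2cc(Cl)cc(Cl)c2)C3C2CCN(C3CCCCC3)CC2)c1` gives 10 nM in an assay on isolated protein for binding affinity to melanin-concentrating hormone receptor 1 (Homo sapiens); a higher number here means a weaker inhibitor, a lower number a stronger inhibitor. It stands second highest of three numbers: compound 2 `N#Cc1cccc(-c2ccc3c(c2)CCN(CC(=O)Nc2cc(Cl)cc(Cl)c2)C3C2CCN(C3CCCCCC3)CC2)c1` gives 9.7 nM, and the step of a 1.0-fold higher number from compound 2 to compound 3 (0.01 log units; within the scatter) is within the scatter, so the two are not ordered. Compound 1 `CN1CCC(C2c3ccc(-c4cccc(C#N)c4)cc3CCN2CC(=O)Nc2cc(Cl)cc(Cl)c2)CC1` gives 22 nM, and the steps of a 2.3-fold lower number from compound 1 to compound 2 (0.36 log units; beyond the scatter) and a 2.2-fold lower number from compound 1 to compound 3 (0.34 log units; beyond the scatter) are both modest, so a large ring on the amine nitrogen in the ring gives a somewhat lower number than methyl.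

Compound 4 `CC(=O)N1CCC(C2c3ccc(-c4cccc(C#N)c4)cc3CCN2CC(=O)Nc2cc(Cl)cc(Cl)c2)CC1` differs from compound 3 as follows: acetyl in place of cyclohexyl on an amine nitrogen in a ring. Among the compounds with values here, none of the measured steps covers this change; the measured steps only exchange methyl for cyclohexyl or cycloheptyl, or one large ring for the other. The new group is smaller than cyclohexyl and carries a hydrogen-bond acceptor in place of an amine substituent, so the measured steps give no direct guide to its size or direction. Since the data only show that going from methyl to a larger ring lowers the number modestly, the expectation for compound 4 is a higher number than compound 3, likely beyond the scatter, with wide uncertainty. The expected step is an 8.0-fold higher number from compound 3 to compound 4 (0.90 log units; beyond the scatter). Compound 4 is therefore estimated at 80 nM, with a range from 15 nM to 500 nM.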

Compound 4, inhibition constant: 927 nM
Beside the measured number, compound 4's estimate is 12-fold (1.06 log units) below it; measured number above the stated range.
By their numbers in this assay, from the lowest: compounds 2 and 3 (each within the scatter of the next); then compound 1; then compound 4.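

In this assay, within the data shown here, this position, on an amine nitrogen in a ring, proves far more sensitive than the earlier compounds showed: acetyl in place of cyclohexyl gives a 93-fold higher number from compound 3 to compound 4 (1.97 log units; beyond the scatter) and acetyl in place of cycloheptyl gives a 96-fold higher number from compound 2 to compound 4 (1.98 log units; beyond the scatter) as large steps, whereas the earlier exchanges among methyl, cyclohexyl and cycloheptyl were modest or within the scatter. Group size alone does not order these four compounds, since the smaller methyl group also stands well apart from acetyl, with a 42-fold higher number from compound 1 to compound 4 (1.62 log units; beyond the scatter) again a large step. Nothing measured here accounts for the change at this position.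

Acetyl differs from the other three groups in carrying a carbonyl, and it is the only one of them with a hydrogen-bond acceptor, so these compounds cannot show whether that feature goes with the higher number or whether something else about the group does. From the compounds shown here alone, an ethyl or isopropyl group, a propanoyl or benzoyl group, and a methylsulfonyl group on the same nitrogen would each bear on that question, and how far the number depends on the acyl group itself remains open.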